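A few compounds are considered here, and "the series" means these few. Any claim that something is new, unique, unknown or untested is made for them only; others in the source may bear on it.

Measured compounds:
compound 1, `CC(=O)NC1=CS(=O)(=O)O[C@@]12[C@@H](CO[Si](C)(C)C(C)(C)C)O[C@@H](n1cc(C)c(=O)n(C)c1=O)[C@@H]2O[Si](C)(C)C(C)(C)C`: in a functional assay on HEL cells (Homo sapiens) (on this read-out higher numbers stand for lower toxicity in this test and lower numbers for higher toxicity in this test), compound 1 gives > 200000 nM, which is a limit of the assay rather than a number.
compound 2, `Cc1cn([C@@H]2O[C@H](CO[Si](C)(C)C(C)(C)C)[C@@]3(OS(=O)(=O)C=C3NC(N)=O)[C@H]2O[Si](C)(C)C(C)(C)C)c(=O)n(C)c1=O`: compound 2 gives 11000 nM.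
compound 3, `Cc1cn([C@@H]2O[C@H](CO[Si](C)(C)C(C)(C)C)[C@@]3(OS(=O)(=O)C=C3NCCC(=O)OCc3ccccc3)[C@H]2O[Si](C)(C)C(C)(C)C)c(=O)n(C)c1=O`: compound 3 gives 200000 nM.

Of the two numbers, compound 2 holds the lowest; its nearest neighbour is compound 3, with an 18-fold higher number from compound 2 to compound 3 (1.26 log units; beyond the scatter). Compound 4, `CCNC(=O)NC1=CS(=O)(=O)O[C@@]12[C@@H](CO[Si](C)(C)C(C)(C)C)O[C@@H](n1cc(C)c(=O)n(C)c1=O)[C@@H]2O[Si](C)(C)C(C)(C)C`, is not yet measured. Its change from compound 2 is ethyl in place of hydrogen on an amide-type nitrogen. The measured steps that bear on it are an at least 18-fold lower number from compound 1 to compound 2 (1.25 log units; beyond the scatter) and an 18-fold higher number from compound 2 to compound 3 (1.26 log units; beyond the scatter); in both, the smaller group on that nitrogen goes with the lower number. A step upward in this assay is therefore expected for compound 4, though smaller than those. Compound 4 is estimated at 30000 nM, within 10000 nM to 120000 nM. This expected change is a 2.7-fold higher number from compound 2 to compound 4 (0.44 log units; beyond the scatter).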

Compound 4, half-maximal cytotoxic concentration: 10000 nM
Compound 4: middle estimate off by 3.0-fold (0.48 log units), on the high side, and the stated range covers the measured number.
By their numbers in this assay, from the lowest: compounds 4 and 2 (each within the scatter of the next); then compound 3.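

In this assay, ethyl in place of hydrogen on this amide-type nitrogen gives a 1.1-fold lower number from compound 2 to compound 4 (0.04 log units; within the scatter), so the earlier link between a smaller group and a lower number does not extend to ethyl. The ethylcarbamoyl group keeps the number low, with a 20-fold lower number from compound 3 to compound 4 (1.30 log units; beyond the scatter) and an at least 20-fold lower number from compound 1 to compound 4 (1.30 log units; beyond the scatter). Compound 1 gives a limit rather than a number: the limit of > 200000 nM in this assay, at which 1 of the 4 values shown sits.

Still open, going by these compounds, is whether a longer chain such as butyl, or a phenyl group, on this nitrogen would stay as close to compound 2 as ethyl does.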